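The compounds below may be only part of what the source reports. "The series", "measured", "known", "first", "only" and "open" are said of these compounds alone.

Three compounds have been measured so far in a functional assay on MDA-MB-231 cells (Homo sapiens) for cytotoxicity, read by MTT assay, with a stated time of 72 h, tested at 5 uM, in the absence of a further agent; on this read-out higher numbers stand for a weaker effect at the one concentration tested and lower numbers for a stronger effect:

compound 1 `CC1(C)CC(=S)Nc2ccc(Cl)cc21` gives 94.3%
compound 2 `CCCNC1=Nc2ccc(Cl)cc2C(C)(C)C1` gives 82.4%
compound 3 `CCN(CC)CCCNC1=Nc2ccc(Cl)cc2C(C)(C)C1` gives 36.1%

Compound 2 stands second highest of the three numbers. Its nearest neighbour is compound 1, which lies higher by a margin beyond the scatter; its furthest is compound 3, reached by a number 46.3 percentage points lower from compound 2 to compound 3 (beyond the scatter), a large drop. Compound 4 `CC1(C)CC(NCc2ccccc2)=Nc2ccc(Cl)cc21` differs from compound 2 by phenyl in place of ethyl on a saturated chain carbon bound to an amine nitrogen, so the propyl becomes a benzyl. Among the compounds with values here, the only measured step that alters the chain on the amine nitrogen is the one from compound 2 to compound 3, and it concerns a different group at a different point of the chain, so it bears only loosely on the present change. A modest lowering is therefore expected, estimated as a number 12.4 percentage points lower from compound 2 to compound 4 (beyond the scatter). Compound 4 is expected to give 70%, within 45% to 95%.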

Compound 4, a percentage reported as activity, at one concentration (the size of the read-out at that concentration, not a potency): 68.1%
Compound 4: middle estimate off by 1.9 percentage points, on the high side, and the stated range covers the measured number.
By their numbers in this assay, from the lowest: compound 3; then compound 4; then compound 2; then compound 1.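

In this assay, replacing the ethyl on a saturated chain carbon bound to an amine nitrogen with phenyl gives a number 14.3 percentage points lower from compound 2 to compound 4 (beyond the scatter), so an aromatic ring at this place, with no diethylamino group, already lowers the number beyond the scatter. Even so, replacing 2-(diethylamino)ethyl with phenyl at the same place gives a number 32 percentage points higher from compound 3 to compound 4 (beyond the scatter), leaving the diethylamino-bearing chain with the lower number of the two. Nothing available explains either step. The compounds shown leave open whether a pyridine ring in place of the phenyl would follow compound 4. They also leave open how a longer chain ending in a piperidine would compare with compound 3.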